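The source may hold more compounds than are shown below. What is called first, only, known or untested is meant among the compounds shown, and "the series" means these compounds.

Measured compounds:
Compound 1 `Cc1ccc2c(=O)c(CSC(=S)N3CCCCC3)coc2c1` — in a functional assay on HeLa cells (Homo sapiens) for antiproliferative activity, read by MTT assay, with a stated time of 72 h (a higher number here means a weaker inhibitor, a lower number a stronger inhibitor), compound 1 gives > 25000 nM, which is a limit of the assay rather than a number.
Compound 2 `Cc1ccc2c(=O)c(CSC(=S)N3CCCC3)coc2c1` — in this assay compound 2 gives 4400 nM.
Compound 3 `Cc1ccc2c(=O)c(CSC(=S)N(C(C)C)C(C)C)coc2c1` — in this assay compound 3 gives 1400 nM.

Compound 2 holds the higher of the two numbers that were obtained; compound 3 is its nearest neighbour, the step being a 3.1-fold lower number from compound 2 to compound 3 (0.50 log units; beyond the scatter). Compound 1 stands only at a limit (the limit of > 25000 nM in this assay, at which 1 of the 3 values shown sits). The steps of an at least 5.6-fold lower number from compound 1 to compound 2 (0.75 log units; beyond the scatter) and an at least 17-fold lower number from compound 1 to compound 3 (1.25 log units; beyond the scatter) are therefore known only as lower bounds of their size.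

Compound 4 `O=c1c(CSC(=S)N2CCCC2)coc2cc(Cl)ccc12` differs from compound 2 by chloro in place of methyl on an aromatic carbon. Among the compounds with values here, all three measured steps concern the amine attached to the thiocarbonyl carbon, and none alters the aromatic ring of the shared core, so no measured step bears directly on this change. The expectation is accordingly a step of no size beyond the scatter, no change at the digits printed from compound 2 to compound 4 (within the scatter). Compound 4 is estimated at 4400 nM in this assay, with a range from 1500 nM to 13000 nM.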

Compound 4, half-maximal inhibitory concentration: 1300 nM
For compound 4 the middle estimate is 3.4-fold (0.53 log units) above the measured one; measured number outside the range, below it.
By their numbers in this assay, from the lowest: compounds 4 and 3 (each within the scatter of the next); then compound 2. At a limit, above all of these: compound 1.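

Until this point every measured step lay in the amine on the thiocarbonyl carbon. With the pyrrolidin-1-yl amine held fixed, this assay now gives a 3.4-fold lower number from compound 2 to compound 4 (0.53 log units; beyond the scatter) for chloro in place of methyl, so the number also responds to this aromatic carbon of the shared core, and exchanging a single heavy atom there is enough for a modest step. No measurement at hand accounts for the size or direction of this step, which rests on one pair of compounds.

On these data alone, whether a bromo or methoxy group on this carbon would lower the number further, or raise it, stays open. Also open, as far as these compounds go, is whether chloro in place of methyl gives a step of similar size when the amine is diisopropylamino or piperidin-1-yl.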